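Alkoxy variation at the benzylic oxygen of a eugenol-derived ether

The compounds below may be only part of what the source reports. "The series", "measured", "known", "first", "only" and "open" are said of these compounds alone.

Compound 1 `C=CCc1cc(OC)c(OC(C)C(OCCCCCCCC)c2ccc(O)c(OC)c2)c(OC)c1`: 86 nM
Compound 2 `C=CCc1cc(OC)c(OC(C)C(OCCCCCCCCCC)c2ccc(O)c(OC)c2)c(OC)c1`: 66 nM
Compound 3 `C=CCc1cc(OC)c(OC(C)C(OC(C)C)c2ccc(O)c(OC)c2)c(OC)c1`: 82 nM

In an assay on HEK293 cells for agonist activity at transient receptor potential cation channel subfamily M member 8 (Homo sapiens), read by fluorescence and calcium flux, with a stated time of 5 min (on this read-out higher numbers stand for an effect only at larger amounts of compound and lower numbers for an effect already at smaller amounts), compound 1 gives 86 nM, the highest of the three numbers, though compound 3 and compound 2 sit within the scatter of it. Compound 4 `C=CCc1cc(OC)c(OC(C)C(OC2CCCCC2)c2ccc(O)c(OC)c2)c(OC)c1` differs from compound 1 in one place: cyclohexyl in place of octyl on an oxygen on a saturated carbon. Among the measured compounds shown here, the steps that bear on this position are a 1.0-fold lower number from compound 1 to compound 3 (0.02 log units; within the scatter) and a 1.2-fold higher number from compound 2 to compound 3 (0.09 log units; within the scatter), both within the scatter, while a 1.3-fold lower number from compound 1 to compound 2 (0.11 log units; within the scatter) also stays within it. The group on this oxygen has thus made no difference beyond the scatter so far, so the author expects a 1.1-fold lower number from compound 1 to compound 4 (0.03 log units; within the scatter), no step beyond the scatter. Compound 4 is therefore estimated at 80 nM, with a range from 40 nM to 160 nM.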

Compound 4, half-maximal effective concentration: 54 nM
Compound 4: middle estimate off by 1.5-fold (0.17 log units), on the high side; low and high end bracket the measured number.
By their numbers in this assay, from the lowest: compounds 4, 2, 3 and 1 (each within the scatter of the next).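

In this assay, putting a ring on this oxygen keeps every step within the scatter, whether the group it replaces is octyl (a 1.6-fold lower number from compound 1 to compound 4 (0.20 log units; within the scatter)), isopropyl (a 1.5-fold lower number from compound 3 to compound 4 (0.18 log units; within the scatter)) or decyl (a 1.2-fold lower number from compound 2 to compound 4 (0.09 log units; within the scatter)). Cyclohexyl therefore joins the open chains: across all four compounds, the group on this oxygen has made no difference beyond the scatter. Nothing available explains this result. Going by these compounds, whether a phenyl ring, an amine or a carboxylic acid in this place would move the number beyond the scatter remains open.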